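Hydroxy for sulfanyl on a naphthyl-substituted quinazoline core

A few compounds are considered here, and "the series" means these few. Any claim that something is new, unique, unknown or untested is made for them only; others in the source may bear on it.

Measured compounds:
compound 1, `Nc1nc(S)c2cc(Sc3ccc4ccccc4c3)ccc2n1`: 6.64
compound 2, `Nc1nc(S)c2cc(S(=O)(=O)c3ccc4ccccc4c3)ccc2n1`: 7.6
compound 3, `Nc1nc(O)c2cc(S(=O)(=O)c3ccc4ccccc4c3)ccc2n1`: 7.96

In an assay for inhibition of Dihydrofolate reductase (Homo sapiens) (a lower number here means a less potent compound, a higher number a more potent compound, by a factor of ten per unit of this negative logarithm), compound 1 stands lowest of the three, with compound 2 the nearest and compound 3 the furthest above it; how the core of compound 1 differs from that of compound 2 is not broken down here. Compound 2 and compound 3 share their core and differ in one place, the change being (hydroxy in place of sulfanyl on an aromatic carbon). This change gives a number 0.36 log units higher from compound 2 to compound 3 (beyond the scatter).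

The same change, (hydroxy in place of sulfanyl on an aromatic carbon), is made from compound 1 to the unmeasured compound 4, `Nc1nc(O)c2cc(Sc3ccc4ccccc4c3)ccc2n1`; among the compounds shown it occurs two times in all, and the place around it is the same in both pairs.

In this assay, for the measured compounds named here, the step from compound 1 to compound 4 is expected to be a number 0.36 log units higher from compound 1 to compound 4 (beyond the scatter), resting on the one measured instance of this change, because a number 0.36 log units higher from compound 2 to compound 3 (beyond the scatter) lies beyond the scatter while still modest. Compound 4 is therefore estimated at 7, expected to fall between 6.5 and 7.5.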

Compound 4, logarithm of the reciprocal of the active concentration, log(1/C): 7.35
The estimate for compound 4 lay 0.35 log units below the measured number; the range from low to high includes it.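

Carried to the second core, in this assay hydroxy in place of sulfanyl on an aromatic carbon gives a number 0.71 log units higher from compound 1 to compound 4 (beyond the scatter). The two steps point the same way and cannot be told apart in size: the same change on two cores in this assay, a number 0.36 log units higher (beyond the scatter) from compound 2 to compound 3 and a number 0.71 log units higher (beyond the scatter) from compound 1 to compound 4, 0.35 log units apart, within the scatter of two such steps. This shows the change carrying over between these two cores, but it does not show that it would carry over to any other core, and it does not explain why the number rises on either one.

The compounds shown hold only sulfanyl and hydroxy at this place, so the result with an amine or a methoxy group there remains open. On these data alone, all four compounds also carry the same naphthyl group, so it also remains open whether the step would hold with a phenyl group in its place.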